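A few compounds are considered here, and "the series" means these few. Any claim that something is new, unique, unknown or untested is made for them only; others in the source may bear on it.

Compound 2 `COc1cc(Cl)cc(-c2nn(-c3cccc(NC(=O)Nc4ccc(Cl)c(C(F)(F)F)c4)c3)cc2-c2ccncc2)c1` stands with the lowest of the two numbers in a functional assay on A549 cells (Homo sapiens) for inhibition, read by sulforhodamine B assay, with a stated time of 48 h, tested at 0.01 uM (a higher number here means a weaker effect of the compound at the concentration tested, a lower number a stronger effect), giving 97%; compound 1 `O=C(Nc1cccc(-n2cc(-c3ccncc3)c(-c3cc(O)cc(Cl)c3)n2)c1)Nc1ccc(Cl)c(C(F)(F)F)c1` gives 101%, and the step of a number 4 percentage points lower from compound 1 to compound 2 (within the scatter) puts the two within the scatter. Compound 3 `COc1cc(Cl)cc(-c2nn(-c3cccc(NC(=O)Nc4cccc(C(F)(F)F)c4)c3)cc2-c2ccncc2)c1` differs from compound 2 by hydrogen in place of chloro on an aromatic carbon. Among the compounds with values here, the only measured step alters a different part of the shared core and stayed within the scatter, so nothing measured here speaks directly to removing the chloro. With both measured values close to no effect, the step of a number 1 percentage points higher from compound 2 to compound 3 (within the scatter) is expected to lie within the scatter. Compound 3 is therefore estimated at 98%, between 85% and 110%.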

Compound 3, a percentage reported as activity, at one concentration (the size of the read-out at that concentration, not a potency): 100%
Beside the measured number, compound 3's estimate is 2 percentage points below it; the measured number falls inside the stated range.
By their numbers in this assay, from the lowest: compounds 2, 3 and 1 (each within the scatter of the next).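

In this assay the step of a number 3 percentage points higher from compound 2 to compound 3 (within the scatter) shows that replacing the chloro of the 4-chloro-3-(trifluoromethyl)phenyl group with hydrogen has no readable effect at this concentration. Because the test compounds all lie close to no effect, this single concentration cannot show whether the chloro matters at all. No evidence here bears on the result. Open, from the compounds shown here alone, is whether an amine or a carboxylic acid at this position would give a number clearly apart from these, and whether the chloro matters at higher concentrations.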